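The compounds below may be only part of what the source reports. "The series", "measured", "known", "first", "only" and "open" are said of these compounds alone.

Going by the values given here, compound 2 `CS(=O)(=O)c1ccc(-c2cnc3[nH]cc(-c4nnc(-c5ccc(F)cc5)o4)c(=O)c3c2)cc1` is one of three compounds measured in a functional assay on HCT-116 cells (Homo sapiens) for inhibition, read by MTT assay, with a stated time of 24 h, tested at 5 uM (on this read-out higher numbers stand for more inhibition of growth at the one concentration tested and lower numbers for less inhibition of growth), where compound 2 gives 14.9%. Compound 1 `N#Cc1ccc(-c2cnc3[nH]cc(-c4nnc(-c5ccc(Cl)cc5)o4)c(=O)c3c2)cc1` gives 17.9% and compound 3 `O=c1c(-c2nnc(-c3ccc(F)cc3)o2)c[nH]c2ncc(-c3ccncc3)cc12` gives 10.9%; the number for compound 2 lies within the scatter of both, so the three compounds cannot be told apart on these data. Compound 4 `CS(=O)(=O)c1ccc(-c2cnc3[nH]cc(-c4nnc(-c5ccccn5)o4)c(=O)c3c2)cc1` differs from compound 2 in one place: pyridin-2-yl in place of 4-fluorophenyl on an aromatic carbon. Among the compounds with values here, no measured step touches this part of the molecule. Within the data shown here, the only measured step, a number 4 percentage points lower from compound 2 to compound 3 (within the scatter), alters another position and stays within the scatter, which at most suggests that single changes to this core move the number little. The expected change for compound 4 is therefore a number 0.9 percentage points lower from compound 2 to compound 4 (within the scatter), within the scatter. Compound 4 is estimated at 14%, ranging from 4% to 26%.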

Compound 4, percent growth inhibition at one concentration: 11.3%
For compound 4 the middle estimate is 2.7 percentage points above the measured one; low and high end bracket the measured number.
By their numbers in this assay, from the lowest: compounds 3, 4, 2 and 1 (each within the scatter of the next).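

Putting pyridin-2-yl in place of 4-fluorophenyl, the first change shown at this position, gives a number 3.6 percentage points lower from compound 2 to compound 4 (within the scatter) in this assay. This position therefore tolerates a six-membered aromatic ring with a hetero atom in place of a carbon-only ring, with no difference these data can resolve. No supporting measurement bears on this result.

On these data alone, it remains open whether an amine or a carboxylic acid on this carbon, rather than an aromatic ring, would move the number beyond the scatter. The other pyridine isomers, pyridin-3-yl and pyridin-4-yl, are also untested here.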